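Stripping a Ring Nitrogen Substituent Down to Hydrogen

The source may hold more compounds than are shown below. What is called first, only, known or untested is meant among the compounds shown, and "the series" means these compounds.

Measured compounds:
compound 1, `CC(C1CC1)n1cc(Nc2nc(N)nc(-c3cccc(-n4ccc5cc(C6CC6)cc(F)c5c4=O)c3CO)n2)cn1`: 1.1%
compound 2, `Cn1cc(Nc2nc(N)nc(-c3cccc(-n4ccc5cc(C6CC6)cc(F)c5c4=O)c3CO)n2)cc1C#N`: 46%

Among the measured compounds shown here, in an ADME assay on microsomes from liver (Mus musculus) for metabolic stability, read by LC-MS, using NADPH, with a stated time of 30 min, tested at 1.5 uM (a higher number here means that more of the compound is left, a lower number that less of the compound is left), compound 1 stands lowest of the two numbers; its only neighbour, compound 2, lies a number 44.9 percentage points higher from compound 1 to compound 2 (beyond the scatter), a large step. Compound 3, `Nc1nc(Nc2cn[nH]c2)nc(-c2cccc(-n3ccc4cc(C5CC5)cc(F)c4c3=O)c2CO)n1`, differs from compound 1 in one place: hydrogen in place of 1-cyclopropylethyl on an aromatic nitrogen. For the measured compounds named here, the one measured step bears on this change only loosely, since it exchanged the whole five-membered ring together with its substituent, whereas the step to compound 3 keeps the ring and removes the substituent alone. That step nonetheless shows that this region can move the read-out far. For compound 3 the step is therefore estimated as a number 18.9 percentage points higher from compound 1 to compound 3 (beyond the scatter), an upward move beyond the scatter that stays smaller than the measured one. Compound 3 is estimated at 20%, within a range from 5% to 45%.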

Compound 3, percent of the compound remaining: 39%
Compound 3: middle estimate off by 19 percentage points, on the low side; the range from low to high includes it.
By their numbers in this assay, from the lowest: compound 1; then compounds 3 and 2 (each within the scatter of the next).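

In this assay, taking 1-cyclopropylethyl off the aromatic nitrogen while the five-membered ring stays gives a number 37.9 percentage points higher from compound 1 to compound 3 (beyond the scatter) and shows that this substituent alone, with no exchange of the ring, is enough to move the read-out far. Exchanging the 5-cyano-1-methyl-1H-pyrrol-3-yl group for 1H-pyrazol-4-yl gives a number 7 percentage points lower from compound 2 to compound 3 (within the scatter) and so leaves the two ring groups apart by no more than the usual scatter in this read-out. Nothing measured here says why the substituent matters so much.

Going by these compounds, it remains open whether a methyl or a cyclopropyl group on the same nitrogen would read like compound 3 or like compound 1. On these data alone, it is equally open how a longer chain ending in an amine or a carboxylic acid would read there.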